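Inverting One Stereocentre of Compound 2

The compounds below may be only part of what the source reports. "The series", "measured", "known", "first", "only" and "open" are said of these compounds alone.

Compound 1 `C=C1C(=O)C2=C3[C@@H](CC[C@H]4C(=C)C(=O)O[C@@H]4[C@@H]13)CC[C@]21C(=O)C[C@H]2C(=C)CC[C@H]3C(=C)C(=O)O[C@@H]3[C@H]21` was tested in a functional assay on C6 cells (Rattus norvegicus) for cytotoxicity, read by CellTiter-Glo, with a stated time of 72 h (on this read-out higher numbers stand for weaker inhibition and lower numbers for stronger inhibition), and gives 6400 nM as its half-maximal inhibitory concentration. Compound 2 `C=C1C(=O)C2=C3[C@H]1[C@H]1OC(=O)C(=C)[C@@H]1CC[C@@]3(O)CC[C@]21C(=O)C[C@H]2C(=C)CC[C@H]3C(=C)C(=O)O[C@@H]3[C@H]21` gives > 10000 nM in this assay and this is a limit of the assay, not a number. Compound 3 `C=C1C(=O)C2=C3[C@H]1[C@H]1OC(=O)C(=C)[C@@H]1CC[C@]3(O)CC[C@]21C(=O)C[C@H]2C(=C)CC[C@H]3C(=C)C(=O)O[C@@H]3[C@H]21` awaits testing and departs from compound 2 in one respect (the two compounds have the same atoms and bonds and differ only in configuration as drawn: 1 of 9 stereo elements differ; a stereocentre at a saturated ring carbon is drawn R in compound 2 and S in compound 3). Within the data shown here, no measured pair shows what such an inversion does, so the expectation rests on compound 1, whose 6400 nM reading is the only number available. Only a small shift toward stronger inhibition is expected in this assay and compound 3 should remain weak. The estimated step of an at least 1.1-fold lower number from compound 2 to compound 3 (0.04 log units; that floor lies within the scatter) is accordingly expected to be modest. The estimate for compound 3 is 9000 nM with an expected range from 3500 nM to 20000 nM on this read-out.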

Compound 3, half-maximal inhibitory concentration: 1200 nM
Beside the measured number, compound 3's estimate is 7.5-fold (0.88 log units) above it, and the stated range ends above it.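

In this assay the inversion gives an at least 8.3-fold lower number from compound 2 to compound 3 (0.92 log units; beyond the scatter), and this shift can be set on configuration alone because nothing else changes: the fact that compounds 2 and 3 differ only in the configuration as drawn. The step has only a floor because of the reading for compound 2: the limit of > 10000 nM in this assay, at which 1 of the 3 values shown sits. Hydroxy in place of hydrogen on a saturated ring carbon, in the configuration drawn in compound 3, goes with a 5.3-fold lower number from compound 1 to compound 3 (0.73 log units; beyond the scatter), so this hydroxy-bearing carbon is now tied to the strongest inhibition among the compounds shown.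

The compounds shown leave open whether a methoxy group, an acetoxy group or an amine in place of the hydroxy on this carbon, drawn S, would keep the reading of compound 3. They also leave open how large the step from compound 2 really is.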